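This account rests on a few compounds, and the source may have more. Where it says the series, first, only, none or still open, it means among the compounds named here.

Measured so far in a functional assay on HT-29 cells (Homo sapiens) for inhibition, read by luminescence and CellTiter-Glo, with a stated time of 24 h; a higher number here means that more compound is needed for the effect, a lower number that less compound is needed:
compound 1 `CCCn1nc(C(=O)N[C@H]2COc3ccccc3N(C)C2=S)nc1Cc1ccccc1`, 288 nM
compound 2 `CN1C(=S)[C@@H](NC(=O)c2nc(Cc3ccccc3)n(CCCC(F)(F)F)n2)COc2ccccc21`, 2380 nM

For the measured compounds named here, compound 2 has the highest number of the two; the only step measured, an 8.3-fold higher number from compound 1 to compound 2 (0.92 log units; beyond the scatter), separates it from compound 1. Compound 3 `CN1C(=S)[C@@H](NC(=O)c2nc(Cc3ccccc3)n(C3CCOC3)n2)COc2ccccc21` is not yet measured. The change is oxolan-3-yl in place of 4,4,4-trifluorobutyl on an aromatic nitrogen. Going by the values given here, the one step that bears on it is an 8.3-fold higher number from compound 1 to compound 2 (0.92 log units; beyond the scatter), which shows that the trifluorobutyl chain of compound 2 carries a higher number than the propyl of compound 1; its removal in compound 3 is expected to return the number at least part of the way. For compound 3 the estimated step is a 4.8-fold lower number from compound 2 to compound 3 (0.68 log units; beyond the scatter), giving an expected 500 nM with a range of 150 nM to 1600 nM.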

Compound 3, half-maximal effective concentration: 1580 nM
Estimate against measurement, compound 3: 3.2-fold (0.50 log units) below; the measured number falls inside the stated range.
By their numbers in this assay, from the lowest: compound 1; then compounds 3 and 2 (each within the scatter of the next).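

In this assay, oxolan-3-yl and 4,4,4-trifluorobutyl on the aromatic nitrogen cannot be told apart (a 1.5-fold lower number from compound 2 to compound 3 (0.18 log units; within the scatter)), although one carries a ring with an oxygen and the other a fluorinated open chain. Against propyl, the oxolan-3-yl group still gives a step beyond the scatter (a 5.5-fold higher number from compound 1 to compound 3 (0.74 log units; beyond the scatter)), so compound 1 keeps the lowest number of the three. Nothing at hand explains this result.

From the compounds shown here alone, it remains open whether a plain butyl chain would group with propyl or with 4,4,4-trifluorobutyl. Going by these compounds, the outcome with a simple methyl at this nitrogen is also open.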